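Dithiocarbamate series: amine swap on the thiocarbonyl carbon

A few compounds are considered here, and "the series" means these few. Any claim that something is new, unique, unknown or untested is made for them only; others in the source may bear on it.

Measured so far in a functional assay on LM7 cells (Homo sapiens) for antiproliferative activity, read by MTT assay, with a stated time of 72 h; on this read-out higher numbers stand for weaker inhibition and lower numbers for stronger inhibition:
- compound 1, `Cc1ccc2c(=O)c(CSC(=S)N3CCCCC3)coc2c1`: 5100 nM
- compound 2, `CC(C)N(C(=S)SCc1coc2ccccc2c1=O)C(C)C`: 21900 nM

Compound 2 carries the diisopropylamino group on the thiocarbonyl carbon and shows the highest of the two numbers; compound 1, its nearest neighbour, sits at a lower number, and that gap lies beyond the scatter. Compounds 1 and 2 differ in two places, so no single step can be read between them.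

Compound 3, `O=c1c(CSC(=S)N2CCCCC2)coc2ccccc12`, is not yet measured in this assay. It differs from compound 2 in one place: piperidin-1-yl in place of diisopropylamino on a thiocarbonyl carbon. Compound 3 thereby shares its amine with compound 1 and its core with compound 2.

A step from compound 2 to compound 3 toward a lower number is expected, because compound 1, which carries the same piperidin-1-yl group, gives 5100 nM. The expected step is a 3.1-fold lower number from compound 2 to compound 3 (0.50 log units; beyond the scatter). For compound 3 the estimate in this assay is 7000 nM, within a range of 2500 nM to 20000 nM.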

Compound 3, half-maximal inhibitory concentration: 4600 nM
Compound 3: middle estimate off by 1.5-fold (0.18 log units), on the high side, within the range that was stated.
By their numbers in this assay, from the lowest: compounds 3 and 1 (each within the scatter of the next); then compound 2.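

In this assay the amine on the thiocarbonyl carbon can now be read as a single change on the shared core: piperidin-1-yl in place of diisopropylamino gives a 4.8-fold lower number from compound 2 to compound 3 (0.68 log units; beyond the scatter) and marks this place as one where the number moves. Hydrogen in place of methyl on an aromatic carbon gives a 1.1-fold lower number from compound 1 to compound 3 (0.04 log units; within the scatter) and so does not separate the two piperidin-1-yl compounds in this assay at all. The amine effect nevertheless rests on one pair of groups and on one core.

Going by these compounds, whether a morpholin-4-yl or a dimethylamino group on the thiocarbonyl carbon would read like piperidin-1-yl or like diisopropylamino stays open, as does the size of the amine step on the methyl-bearing core of compound 1. No measurement bearing on the origin of the amine step is at hand.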